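The compounds below may be only part of what the source reports. "The series", "measured", "known", "first", "only" and "open" are said of these compounds alone.

Three compounds of the series have numbers in a functional assay on PC-3 cells (Homo sapiens) for inhibition, read by MTT assay, with a stated time of 48 h; on this read-out lower numbers stand for stronger inhibition and higher numbers for weaker inhibition. Compound 1 `C=C1CC[C@@H]2[C@](C)(CO)[C@H](O)CC[C@@]2(C)[C@@H]1CC(Sc1ccc([N+](=O)[O-])cc1)C1=CCOC1=O` gives 17000 nM. Among the compounds with values here, compound 2 `C=C1CC[C@@H]2[C@](C)(CO)[C@H](O)CC[C@@]2(C)[C@@H]1CC(Sc1ncccn1)C1=CCOC1=O` gives 7000 nM; the only single-place step measured so far, a 2.4-fold lower number from compound 1 to compound 2 (0.39 log units; beyond the scatter), sits on the aryl group that hangs on the sulfur. Compound 3 `C=C1CC[C@@H]2[C@](C)(CO)[C@H](O)CC[C@@]2(C)[C@@H]1C/C=C1/C(=O)OC[C@H]1OC(=O)CSc1ccc(C)cc1` gives 27000 nM, the highest of the three numbers; its gap to compound 1 lies within the scatter, its gap to compound 2 beyond it.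

Compound 4 `C=C1CC[C@@H]2[C@](C)(CO)[C@H](O)CC[C@@]2(C)[C@@H]1C/C=C1/C(=O)OC[C@H]1OC(=O)CCCSc1ccc(F)cc1` carries the change (2-((4-fluorophenyl)sulfanyl)ethyl in place of (4-methylphenyl)sulfanyl on a saturated chain carbon bound to a carbonyl carbon). Within the data shown here, no measured step touches this place on the chain bound to the carbonyl carbon; the step from compound 1 to compound 2 concerns a different position and a different kind of exchange, so it offers no direct guide. Among the measured compounds shown here, with no step of the same kind on record, the expectation is a step of a 1.1-fold lower number from compound 3 to compound 4 (0.03 log units; within the scatter) that stays within the scatter, in no fixed direction. Compound 4 is therefore estimated at 25000 nM in this assay, with a range from 8000 nM to 75000 nM.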

Compound 4, half-maximal inhibitory concentration: 12000 nM
Compound 4: the middle estimate sits 2.1-fold (0.32 log units) above what was measured; the measured number falls inside the stated range.
By their numbers in this assay, from the lowest: compounds 2, 4, 1 and 3 (each within the scatter of the next, the first and the last beyond it).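

In this assay, the saturated chain carbon bound to a carbonyl carbon responds to substitution: 2-((4-fluorophenyl)sulfanyl)ethyl in place of (4-methylphenyl)sulfanyl gives a 2.3-fold lower number from compound 3 to compound 4 (0.35 log units; beyond the scatter) and the step is modest. Within the data shown here, this is the first measured step at this place, and it shows that the sulfanyl-bearing chain there can be altered with a change beyond the scatter, in the direction of stronger inhibition. No measured evidence on any property bears on this step, so no cause can be assigned.

This one exchange alters the chain and the ring substituent together, leaving the separate shares of the added chain carbons and of fluorine in place of methyl unresolved. Also open, going by these compounds, is how this place responds to an amine, a carboxylic acid or a still longer chain.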